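Changing the triazole substituent from bromobenzyl to octyl

The compounds below may be only part of what the source reports. "The series", "measured", "known", "first", "only" and "open" are said of these compounds alone.

Compound 1 `CCCCCCCCn1cc(/C=C/C(=O)c2ccc(NC(=O)CN3CCN(c4ccccc4F)CC3)cc2)nn1`: 68600 nM
Compound 2 `CCCCCCCCn1cc(/C=C/C(=O)c2ccc(NC(=O)CN3CCN(C(=O)OC(C)(C)C)CC3)cc2)nn1`: 98400 nM
Compound 3 `COc1ccccc1N1CCN(CC(=O)Nc2ccc(C(=O)/C=C/c3cn(Cc4ccc(Br)cc4)nn3)cc2)CC1`: 36800 nM

In a functional assay on MCF7 cells (Homo sapiens) for inhibition, read by MTT assay (on this read-out lower numbers stand for stronger inhibition and higher numbers for weaker inhibition), compound 3 gives the lowest of the three numbers; compound 1 sits within the scatter of it, while compound 2 lies beyond. Compound 4 `CCCCCCCCn1cc(/C=C/C(=O)c2ccc(NC(=O)CN3CCN(c4ccccc4OC)CC3)cc2)nn1` has not been measured. It differs from compound 3 by heptyl in place of 4-bromophenyl on a saturated chain carbon bound to an aromatic nitrogen. Among the compounds with values here, the one step measured, a 1.4-fold higher number from compound 1 to compound 2 (0.16 log units; within the scatter), touches a different place and so says little here. Compound 1 already carries the octyl group, and its value and that of compound 3 show no difference beyond the scatter. The step from compound 3 to compound 4 is therefore expected to be small, a 1.4-fold higher number from compound 3 to compound 4 (0.13 log units; within the scatter). Compound 4 is estimated at 50000 nM, within 20000 nM to 130000 nM.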

Compound 4, half-maximal inhibitory concentration: 30000 nM
Compound 4: the middle estimate sits 1.7-fold (0.22 log units) above what was measured; the measured number falls inside the stated range.
By their numbers in this assay, from the lowest: compounds 4, 3, 1 and 2 (each within the scatter of the next, the first and the last beyond it).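

In this assay, the step from 4-bromobenzyl to octyl is a 1.2-fold lower number from compound 3 to compound 4 (0.09 log units; within the scatter) and stays within the scatter, so at this position a chain and a ring-bearing group could not be told apart. With octyl held, a 3.3-fold lower number from compound 2 to compound 4 (0.52 log units; beyond the scatter) for 2-methoxyphenyl in place of tert-butoxycarbonyl, and a 2.3-fold lower number from compound 1 to compound 4 (0.36 log units; beyond the scatter) for methoxy in place of fluoro, both lie beyond the scatter. No measurement shown here accounts for these steps.

As far as these compounds go, what a longer chain such as dodecyl, or an octyl chain ending in an amine or a carboxylic acid, would give at this position remains open.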